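A few compounds are considered here, and "the series" means these few. Any claim that something is new, unique, unknown or untested is made for them only; others in the source may bear on it.

Two compounds share one core and differ only in the chain attached to the amine nitrogen. Compound 1 `OCCCNCc1nc2c(OCC3CCCCC3)cccc2[nH]1` and compound 2 `OCCCCCNCc1nc2c(OCC3CCCCC3)cccc2[nH]1` were both tested in an assay on cells for inhibition of interleukin-5 receptor subunit alpha (Mus musculus), read by WST assay, with a stated time of 48 h, tested at 30 uM, in the presence of a further agent that is not named here; a lower number here means less inhibition, a higher number more inhibition at the concentration tested (going by the name of the read-out): compound 1 gives 52.7%, and compound 2 gives 23.7%. For the measured compounds named here, compound 2 thus stands lowest of the two numbers, and the only measured step, a number 29 percentage points lower from compound 1 to compound 2 (beyond the scatter), links the longer chain with less inhibition.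

Compound 3 `CCC(CO)NCc1nc2c(OCC3CCCCC3)cccc2[nH]1` has not been measured yet. It differs from compound 2 in one place: 1-(hydroxymethyl)propyl in place of 5-hydroxypentyl on an amine nitrogen. Going by the values given here, the entering group is smaller than the leaving one, so the one step that bears on it points back upward, and a step of roughly that size in the opposite direction is expected.

Because a number 29 percentage points lower from compound 1 to compound 2 (beyond the scatter) was modest but beyond the scatter, compound 3 is expected to give about 42% in this assay, within 18% to 65%, an expected rise of a number 18.3 percentage points higher from compound 2 to compound 3 (beyond the scatter).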

Compound 3, a percentage reported as inhibition, at one concentration (the size of the read-out at that concentration, not a potency): 94.3%
The estimate for compound 3 lay 52.3 percentage points below the measured number; the measured number lies above the stated range.
By their numbers in this assay, from the lowest: compound 2; then compound 1; then compound 3.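

The group on the amine nitrogen matters more than the first pair suggested: in this assay, 1-(hydroxymethyl)propyl in place of 5-hydroxypentyl gives a number 70.6 percentage points higher from compound 2 to compound 3 (beyond the scatter), and in place of 3-hydroxypropyl it gives a number 41.6 percentage points higher from compound 1 to compound 3 (beyond the scatter). Chain length alone therefore does not tell the story, since 1-(hydroxymethyl)propyl and 5-hydroxypentyl have the same counts of hydrogen-bond donors and acceptors, and neither has a ring or a net charge, yet the numbers lie far apart. Nothing measured here explains why this group stands out.

The compounds shown cannot separate the effect of the branch from that of the ethyl arm or the place of the hydroxy group. Going by these compounds, it also remains open whether an amine or a carboxylic acid in place of that hydroxy group would keep the high number seen with compound 3.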